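Methyl substitution on the aminophenyl ring of a pyrrolopyridine series

This account rests on a few compounds, and the source may have more. Where it says the series, first, only, none or still open, it means among the compounds named here.

Measured compounds:
compound 1, `Nc1cc(-c2cnc3[nH]cc(-c4ccncc4)c3c2)ccc1Cl`, 12000 nM
compound 2, `Nc1cccc(-c2cnc3[nH]cc(-c4ccncc4)c3c2)c1`, 2300 nM
compound 3, `CS(=O)(=O)Nc1cc(N)cc(-c2cnc3[nH]cc(-c4ccncc4)c3c2)c1`, a limit, > 30000 nM

Of the compounds shown here, three sharing one core have been tested in a functional assay on MCF7 cells (Homo sapiens) for cytotoxicity, read by MTT assay, with a stated time of 48 h; a higher number here means a weaker inhibitor, a lower number a stronger inhibitor. Compound 1 gives 12000 nM and compound 2 gives 2300 nM. Compound 3 reaches only a limit of the assay, > 30000 nM. Compound 2 therefore stands lowest of the two numbers shown, with the nearest number being that of compound 1.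

The step to compound 4, `Cc1ccc(-c2cnc3[nH]cc(-c4ccncc4)c3c2)cc1N`, is methyl in place of hydrogen on an aromatic carbon. Among the compounds with values here, two measured steps bear on it. Removing the chloro from the carbon ortho to the amino group gave a 5.2-fold lower number from compound 1 to compound 2 (0.72 log units; beyond the scatter), so a substituent at that place raised the number. Adding a methanesulfonamido gave an at least 13-fold higher number from compound 2 to compound 3 (1.11 log units; beyond the scatter), with compound 3 at the limit (the limit of > 30000 nM in this assay, at which 1 of the 3 values shown sits). Both steps show that adding a group to the aminophenyl ring raises the number, and a methyl at the place of the former chloro is expected to do likewise, though the methyl is smaller than the earlier groups, so a modest rise is expected, a 2.6-fold higher number from compound 2 to compound 4 (0.42 log units; beyond the scatter). For compound 4 the expected value in this assay is 6000 nM, within a range from 2000 nM to 20000 nM.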

Compound 4, half-maximal inhibitory concentration: 2800 nM
Compound 4: the middle estimate sits 2.1-fold (0.33 log units) above what was measured; the measured number falls inside the stated range.
By their numbers in this assay, from the lowest: compounds 2 and 4 (each within the scatter of the next); then compound 1. At a limit, above all of these: compound 3.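

In this assay, methyl in place of hydrogen on the aromatic carbon ortho to an amino group stays within the scatter (compare a 1.2-fold higher number from compound 2 to compound 4 (0.09 log units; within the scatter)). A group at this carbon therefore does not raise the number merely by being there, which the earlier chloro step could not show. Methyl in place of chloro on the same carbon separates the two groups (here a 4.3-fold lower number from compound 1 to compound 4 (0.63 log units; beyond the scatter)), although nothing measured here accounts for that difference.

As far as these compounds go, whether an ethyl, a methoxy or a fluoro at this carbon would stay with methyl or move with chloro remains open. Also open is how a methyl on another carbon of this ring would read, since only this one place has been probed with it in the compounds shown.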